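A few compounds are considered here, and "the series" means these few. Any claim that something is new, unique, unknown or untested is made for them only; others in the source may bear on it.

Compound 1 `COc1cc2c(Oc3ccc(NC(=O)C4(c5nnc(-c6ccc(F)cc6)o5)CC4)cc3F)ccnc2cc1OCCCN1CCCC1`: 2340 nM. Compound 2 `COc1cc2nccc(Oc3ccc(NC(=O)c4nnc(-c5ccc(F)cc5)o4)cc3)c2cc1OC`: > 100000 nM. Compound 3 `COc1cc2c(Oc3ccc(NC(=O)c4cc(-c5ccc(F)cc5)on4)cc3)ccnc2cc1OCCCN1CCC(C)CC1`: 2040 nM.

In a functional assay on PC-3 cells (Homo sapiens) for antiproliferative activity, read by MTT assay, with a stated time of 72 h (on this read-out lower numbers stand for stronger inhibition and higher numbers for weaker inhibition), compound 3 holds the lowest of the two numbers, and compound 1 sits within the scatter of it. For compound 2 the entry is not a number but a limit of the assay (the limit of > 100000 nM in this assay, at which 1 of the 3 values shown sits). Compound 4 `COc1cc2c(Oc3ccc(NC(=O)c4nnc(-c5ccc(F)cc5)o4)cc3)ccnc2cc1OCCCN1CCC(C)CC1` is compound 3 with one change: 5-(4-fluorophenyl)-1,3,4-oxadiazol-2-yl in place of 5-(4-fluorophenyl)-1,2-oxazol-3-yl on a carbonyl carbon. Going by the values given here, no measured pair shows this change by itself. Compound 2 also carries the 5-(4-fluorophenyl)-1,3,4-oxadiazol-2-yl on the carbonyl carbon and reaches only a limit there. A loss beyond the scatter is therefore expected, a 3.9-fold higher number from compound 3 to compound 4 (0.59 log units; beyond the scatter). Compound 4 is estimated at 8000 nM, with a range from 1500 nM to 50000 nM.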

Compound 4, half-maximal inhibitory concentration: 3810 nM
Estimate against measurement, compound 4: 2.1-fold (0.32 log units) above, within the range that was stated.
By their numbers in this assay, from the lowest: compounds 3, 1 and 4 (each within the scatter of the next). At a limit, above all of these: compound 2.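

In this assay, 5-(4-fluorophenyl)-1,3,4-oxadiazol-2-yl in place of 5-(4-fluorophenyl)-1,2-oxazol-3-yl on the carbonyl carbon gives a 1.9-fold higher number from compound 3 to compound 4 (0.27 log units; within the scatter), so the two rings are not told apart at this position. With that oxadiazole kept, 2-(4-methylpiperidin-1-yl)ethyl in place of hydrogen on a saturated chain carbon bound to an oxygen on an aromatic ring gives an at least 26-fold lower number from compound 2 to compound 4 (1.41 log units; beyond the scatter). The entry for compound 2 is a limit, not a number: the limit of > 100000 nM in this assay, at which 1 of the 4 values shown sits.

Still open, on these data alone, is how a morpholine would compare with the 4-methylpiperidine at the chain end. Also open, as far as these compounds go, is whether chlorine could replace the fluorine on the phenyl ring.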